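Series notes: cytotoxicity, from compound 3 to compound 4

The compounds below may be only part of what the source reports. "The series", "measured", "known", "first", "only" and "open" are said of these compounds alone.

Measured compounds:
- compound 1 `CC1=NN(C(=O)c2ccc([N+](=O)[O-])cc2)C(c2ccccc2O)C1`: 30100 nM
- compound 2 `CC(=O)Oc1ccccc1C1CC(C)=NN1C(=O)CN1CCC(C(C)=O)CC1`: 7800 nM
- compound 3 `O=C(c1ccccc1)N1N=C(c2cc3ccccc3oc2=O)CC1c1ccccc1`: 36600 nM

All three numbers come from a functional assay on HepG2 cells (Homo sapiens) for cytotoxicity, read by MTT assay, with a stated time of 48 h; on this read-out lower numbers stand for stronger inhibition and higher numbers for weaker inhibition. Compound 3 stands highest of the three. Its gap to compound 1 lies within the scatter, so the two cannot be ordered. Its gap to compound 2 lies beyond the scatter, compound 2 giving the lower number.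

Compound 4 `O=C(CNC1CCCCC1)N1N=C(c2cc3ccccc3oc2=O)CC1c1ccccc1` differs from compound 3 in one place: (cyclohexylamino)methyl in place of phenyl on a carbonyl carbon. Among the measured compounds shown here, no pair of measured compounds isolates this change, so its effect is not known from the set. For the measured compounds named here, the only hint is that compound 2, whose carbonyl carbon also bears an amine-containing group, gives the lowest number of the three, while compound 3 with a plain phenyl on that carbon gives the highest; but compound 2 differs from compound 3 in several other places, so the values of that pair show only that much.

The step of a 2.0-fold lower number from compound 3 to compound 4 (0.31 log units; beyond the scatter) is expected to be a modest decrease, near the edge of the scatter. Compound 4 is expected to give 18000 nM, with a range from 6000 nM to 55000 nM.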

Compound 4, half-maximal inhibitory concentration: 34400 nM
Compound 4: the middle estimate sits 1.9-fold (0.28 log units) below what was measured; the measured number falls inside the stated range.
By their numbers in this assay, from the lowest: compound 2; then compounds 1, 4 and 3 (each within the scatter of the next).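

In this assay the replacement on the carbonyl carbon gives a 1.1-fold lower number from compound 3 to compound 4 (0.03 log units; within the scatter) and so separates the two compounds by no more than repeat measurements would. On the core of compound 3, a (cyclohexylamino)methyl group with its amine nitrogen and a plain phenyl cannot be told apart at this position, so an amine-bearing group here is not enough by itself to shift the number. No measurement at hand accounts for this result.

Still open, going by these compounds, is whether a morpholinomethyl or dimethylaminomethyl group, or a longer chain carrying the amine, would stand apart from compound 3 on this carbonyl carbon. Also open, on these data alone, is whether the same replacement would behave alike on a core other than that of compound 3.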